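A few compounds are considered here, and "the series" means these few. Any claim that something is new, unique, unknown or untested is made for them only; others in the source may bear on it.

Compound 2, with structure `CC(C)C(=O)COc1nc(N)nc2nc[nH]c12`, is known only as a limit in an assay on HT-29 cells with Methylated-DNA--protein-cysteine methyltransferase (Homo sapiens) as the target; a lower number here means a stronger inhibitor, a higher number a weaker inhibitor: in this assay compound 2 gives > 1000000 nM, a limit of the assay rather than a number. Compound 1, with structure `Nc1nc(OCC2CC=CCC2)c2[nH]cnc2n1`, is also known only as a limit, giving > 1000000 nM in this assay. Among the compounds with values here, their one measured step, a step that the two limits leave unreadable from compound 1 to compound 2, cannot be read, since both values sit at the limit (the limit of > 1000000 nM in this assay, at which 2 of the 2 values shown sit). Compound 3, with structure `Nc1nc(OCC(=O)c2ccccc2)c2[nH]cnc2n1`, differs from compound 2 by phenyl in place of isopropyl on a carbonyl carbon. Within the data shown here, no measured step bears on this change, so compound 3 is expected to remain near the limit, with an estimated step of a number no higher from compound 2 to compound 3 (the limit leaves the size open) and an estimated value of 1000000 nM, within the range 100000 nM to 3000000 nM.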

Compound 3, half-maximal inhibitory concentration: > 1000000 nM
Compound 3: a limit, no number; the forecaster's own chance of this, stated with the estimate: 80%; the middle value lies on the limit itself.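

Compound 3 also gives only a limit, so no step from compound 2 to compound 3 can be read: the limit of > 1000000 nM in this assay, at which 3 of the 3 values shown sit.

The compounds shown leave open what number any of them would reach in this assay, and whether phenyl and isopropyl on a carbonyl carbon differ at all.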